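Removing One Methyl from a Side Chain

A few compounds are considered here, and "the series" means these few. Any claim that something is new, unique, unknown or untested is made for them only; others in the source may bear on it.

In a functional assay on HCC827 cells (Homo sapiens) for inhibition, read by fluorescence, with a stated time of 72 h (on this read-out higher numbers stand for weaker inhibition of growth and lower numbers for stronger inhibition of growth), compound 1 `CCCCn1cnc2c(NCc3cccc(Cl)c3)nc(N[C@H]3CC[C@H](N)CC3)nc21` gives 10600 nM. Compound 2 `CC(C)CCn1cnc2c(Nc3ccccc3)nc(N[C@H]3CC[C@H](N)CC3)nc21` gives 21700 nM, the higher of the two numbers and so the weaker inhibition of growth, by a gap beyond the scatter. Compound 3 `CCCCn1cnc2c(Nc3ccccc3)nc(N[C@H]3CC[C@H](N)CC3)nc21` differs from compound 2 by one small change, hydrogen in place of methyl on a saturated chain carbon bound to two saturated chain carbons, which turns isopentyl to butyl. Within the data shown here, no measured pair shows this change alone. A small step within the scatter, toward a slightly lower number, is expected: a 1.3-fold lower number from compound 2 to compound 3 (0.11 log units; within the scatter). The estimated value for compound 3 is 17000 nM, with an expected range from 8000 nM to 32000 nM.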

Compound 3, concentration for 50% growth inhibition: 9000 nM
Compound 3: the middle estimate sits 1.9-fold (0.28 log units) above what was measured; the measured number falls inside the stated range.
By their numbers in this assay, from the lowest: compounds 3 and 1 (each within the scatter of the next); then compound 2.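

In this assay, going from isopentyl to butyl gives a 2.4-fold lower number from compound 2 to compound 3 (0.38 log units; beyond the scatter), so this single methyl on the side chain has a modest but real effect on the number. With butyl on the core, phenyl in place of 3-chlorobenzyl on the nitrogen gives a 1.2-fold lower number from compound 1 to compound 3 (0.07 log units; within the scatter), a change that stays within the scatter. No evidence here explains either result. From the compounds shown here alone, whether a shorter propyl chain, a longer pentyl chain or a chain ending in an amine would lower the number further remains open. So does whether removing this methyl has the same effect with 3-chlorobenzyl on the nitrogen.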